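The compounds below may be only part of what the source reports. "The series", "measured", "known", "first", "only" and "open" are said of these compounds alone.

Measured so far in an ADME assay on C3H 10T1/2 cells (Mus musculus) for cytotoxicity, read by fluorescence, with a stated time of 24 h; on this read-out lower numbers stand for stronger inhibition and higher numbers for weaker inhibition:
- compound 1 `CC(C)=CCC/C(C)=C/Cc1c(CCC(=O)c2ccc(O)cc2O)ccc(O)c1O`: > 75000 nM, a limit
- compound 2 `C/C(=C\Cc1c(CCC(=O)c2ccc(O)cc2O)ccc(O)c1O)CCCC(C)(C)O`: > 75000 nM, a limit

Compound 2 has no number, only the limit > 75000 nM. Its standing in the series is no more than this: the limit of > 75000 nM in this assay, at which 2 of the 2 values shown sit.

Compound 3 `COC(C)(C)CCC/C(C)=C/Cc1c(CCC(=O)c2ccc(O)cc2O)ccc(O)c1O` follows from compound 2 by one change, methyl in place of hydrogen on an oxygen on a saturated carbon, which turns hydroxy into methoxy.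

For the measured compounds named here, only one measured step bears on this, and it is a different change: a step that the two limits leave unreadable from compound 1 to compound 2. It gives no size and no direction to carry over. With compound 2 at the limit > 75000 nM, no step beyond the scatter is expected, and compound 3 may well be reported only as a limit too.

The expected step is a step that the limit leaves unreadable from compound 2 to compound 3.

The estimate for compound 3 is 80000 nM, with an expected range of 35000 nM to 150000 nM.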

Compound 3, half-maximal inhibitory concentration: > 75000 nM
Compound 3 ended at the assay's limit (the forecaster's own chance of this, stated with the estimate: 80%); the middle value does not contradict the limit.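

No step can be read among compound 1, compound 2 and compound 3, as all three results are limits. Left open is where any of the three would give an actual number in this assay and so whether hydroxy to methoxy changes anything.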